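This account rests on a few compounds, and the source may have more. Where it says the series, first, only, none or still open, it means among the compounds named here.

Working notes on the series, which so far has two measured members sharing one core. In an ADME assay on BHK-21 cells (Mesocricetus auratus) for cytotoxicity, read by MTT assay, with a stated time of 72 h (on this read-out higher numbers stand for lower toxicity in this test and lower numbers for higher toxicity in this test), compound 1 `FC(F)(F)c1ccc(NCc2cn(-c3ccccc3)nc2-c2ccc(C(F)(F)F)cc2)cc1` gives 27000 nM. Compound 2 `Brc1ccc(NCc2cn(-c3ccccc3)nc2-c2ccc(Br)cc2)cc1` gives > 100000 nM, which is a limit of the assay and not a number. Going by the values given here, compound 2 therefore has no exact position on the scale, and no single-place step yet links the two measured compounds.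

Compound 3 `FC(F)(F)c1ccc(-c2nn(-c3ccccc3)cc2CNc2ccc(Br)cc2)cc1` follows from compound 2 by trifluoromethyl in place of bromo on an aromatic carbon, para to a large group, which reads as 4-bromophenyl to 4-(trifluoromethyl)phenyl. Compound 3 thus shares this trifluoromethyl group with compound 1 and keeps its remaining bromo from compound 2.

Compound 3 is expected to read lower than compound 2 in this assay, moving toward compound 1 at 27000 nM without necessarily reaching it. The expected change is an at least 1.8-fold lower number from compound 2 to compound 3 (0.25 log units; that floor lies within the scatter), and its size is loosely estimated, with a reading at the limit still possible. For compound 3 the estimated value is 55000 nM, with an expected range of 22000 nM to 100000 nM.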

Compound 3, half-maximal cytotoxic concentration: 28000 nM
Compound 3: the middle estimate sits 2.0-fold (0.29 log units) above what was measured; measured number inside the range.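

In this assay, going by these compounds alone, trifluoromethyl in place of bromo on an aromatic carbon, para to a large group, gives an at least 3.5-fold lower number from compound 2 to compound 3 (0.55 log units; beyond the scatter), the first step that can be read and one that lies beyond the scatter. Within the data shown here, with that 4-(trifluoromethyl)phenyl held constant, the single change at the second place, bromo in place of trifluoromethyl on an aromatic carbon, gives a 1.0-fold higher number from compound 1 to compound 3 (0.02 log units; within the scatter), so in this pair the group at the second place makes no difference that can be told from the scatter. Compound 2 stands at a limit of the assay and not at a number, so the step into compound 3 has a floor and no upper size: the limit of > 100000 nM in this assay, at which 1 of the 3 values shown sits.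

From the compounds shown here alone, only bromo and trifluoromethyl appear at the position para to a large group, so it stays open whether the lower number follows trifluoromethyl in particular or would also come with a nitrile, a methoxy group or a carboxylic acid there. It also stays open whether the second place stays without effect when the 4-bromophenyl is present, since a step at that place is shown only with the 4-(trifluoromethyl)phenyl in the molecule.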